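The source may report more compounds than this note shows. Statements on the series, on what has been measured and on what is new or still open speak of the compounds shown alone.

In a functional assay on a cell-free system (plasma, Homo sapiens) for inhibition, with Plasma (Rattus norvegicus) as the target (on this read-out lower numbers stand for stronger inhibition and higher numbers for weaker inhibition), compound 1 `Cc1c(OCc2cccnc2)ccc2c(N3CCNCC3)cc(=O)oc12` gives 980 nM and compound 2 `CCCOc1ccc2c(N3CCNCC3)cc(=O)oc2c1C` gives 2950 nM while compound 3 `CSCOc1ccc2c(N3CCNCC3)cc(=O)oc2c1C` gives 900 nM on the same scale. Compound 3 therefore shares the low end of this small set with compound 1, and only compound 2 stands apart. The two gaps show this clearly (a 1.1-fold lower number from compound 1 to compound 3 (0.04 log units; within the scatter) and a 3.3-fold lower number from compound 2 to compound 3 (0.52 log units; beyond the scatter)).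

Compound 4 `CCOCOc1ccc2c(N3CCNCC3)cc(=O)oc2c1C` keeps the shared core and differs from compound 3 in one group, with ethoxy in place of methylsulfanyl on a saturated chain carbon bound to an oxygen on an aromatic ring. Among the measured compounds shown here, no measured step introduces ethoxy itself. All three measured steps change this same place, however, and the third of them is also modest (a 3.0-fold higher number from compound 1 to compound 2 (0.48 log units; beyond the scatter)). The most relevant comparison is the step from ethyl to methylsulfanyl, which lowered the number, and ethoxy brings an ethyl back at the end of the chain. A small move towards a higher number is therefore expected in this assay, though probably not the full distance to compound 2. The estimated step is small (a 1.8-fold higher number from compound 3 to compound 4 (0.25 log units; within the scatter)). For compound 4 the expected value is 1600 nM with an estimated range from 700 nM to 3500 nM as the likely span.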

Compound 4, half-maximal inhibitory concentration: 1800 nM
Compound 4: the middle estimate sits 1.1-fold (0.05 log units) below what was measured, and the stated range covers the measured number.
By their numbers in this assay, from the lowest: compounds 3, 1, 4 and 2 (each within the scatter of the next, the first and the last beyond it).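

In this assay, compound 4 cannot be separated from any of the three earlier compounds, since a 2.0-fold higher number from compound 3 to compound 4 (0.30 log units; within the scatter), a 1.6-fold lower number from compound 2 to compound 4 (0.21 log units; within the scatter) and a 1.8-fold higher number from compound 1 to compound 4 (0.26 log units; within the scatter) all lie within the usual scatter. The earlier set held one clear contrast at this place on the chain, a 3.3-fold lower number from compound 2 to compound 3 (0.52 log units; beyond the scatter), and the ethoxy group of compound 4 falls within the scatter of both ends of that gap, so this compound cannot be assigned to either end. Swapping methylsulfanyl for ethoxy therefore gives a step too small to read as a real change, and nothing available here explains the differences seen at this place.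

The four compounds leave open whether a chain ending in an amine or a carboxylic acid, or a longer chain such as a hexyl group, would move the number beyond the scatter in either direction. On these data alone, they also vary only this one place, so how a change elsewhere on the shared core would act, alone or together with these groups, remains unknown.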